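Notes on the cyclobutylamino variant of compound 1

The source may report more compounds than this note shows. Statements on the series, on what has been measured and on what is new or still open speak of the compounds shown alone.

Measured so far in a functional assay for antagonist activity at adenosine receptor A1 (Homo sapiens); on this read-out lower numbers stand for stronger inhibition and higher numbers for weaker inhibition:
compound 1 `CCCn1c(=O)c2nc(C3CCCC(N)C3)[nH]c2n(CCC)c1=O` gives 50 nM
compound 2 `CCCn1c(=O)c2nc(C3CCCC(NC(C)=O)C3)[nH]c2n(CCC)c1=O` gives 41 nM
compound 3 `CCCn1c(=O)c2nc(C3CCC(C(=O)N(C)CCN(C)C)CC3)[nH]c2n(CCC)c1=O` gives 17 nM; 85 nM (2 entries)

Compound 1 stands at the higher of the two single numbers; the step of a 1.2-fold lower number from compound 1 to compound 2 (0.09 log units; within the scatter) lies within the scatter, and compound 3 has no single number, only (the several entries of compound 3 in this assay, 17 nM; 85 nM (2 entries)).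

Compound 4 `CCCn1c(=O)c2nc(NC3CCC3)[nH]c2n(CCC)c1=O` carries the change (cyclobutylamino in place of 3-aminocyclohexyl on an aromatic carbon). Within the data shown here, no measured step touches this kind of change; the only measured step, acetylation of the amine, stayed within the scatter, and the spread of the compound 3 entries shows how far repeated values of one compound can lie apart. No direction beyond the scatter is therefore expected, and the step of a 2.0-fold higher number from compound 1 to compound 4 (0.30 log units; within the scatter) is an estimate with wide bounds. Compound 4 is expected at 100 nM, in the range 25 nM to 500 nM.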

Compound 4, inhibition constant: 2.6 nM
Compound 4: the middle estimate sits 38-fold (1.59 log units) above what was measured; the whole stated range lies above it.
By their numbers in this assay, from the lowest: compound 4; then compounds 2 and 1 (each within the scatter of the next).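

The group on this aromatic carbon, between two ring nitrogen atoms, matters far more in this assay than the acetylation on the amine nitrogen did: cyclobutylamino in place of 3-aminocyclohexyl gives a 19-fold lower number from compound 1 to compound 4 (1.28 log units; beyond the scatter) against a step within the scatter for that acetylation. This step also exceeds the widest spread of repeated values seen in the series: the several entries of compound 3 in this assay, 17 nM; 85 nM (2 entries).

Among these compounds, the amino link and the four-membered ring enter together, so the single step cannot separate them. Cyclopentylamino, cyclohexylamino or a directly attached cyclobutyl group would tell which of the two carries the lower number.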